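A few compounds are considered here, and "the series" means these few. Any claim that something is new, unique, unknown or untested is made for them only; others in the source may bear on it.

Measured compounds in this set:
compound 1 `COc1ccc(/C=C/c2cc(OC)cc(OC)c2/C=C/C(=O)NC2CC2)cc1` — 8810 nM
compound 2 `C#CCNC(=O)/C=C/c1c(/C=C/c2ccc(OC)cc2)cc(OC)cc1OC` — 6930 nM
compound 3 `COc1ccc(/C=C/c2cc(OC)cc(OC)c2/C=C/C(=O)N2CCCCC2)cc1` — 10600 nM

All three numbers come from a functional assay on A549 cells (Homo sapiens) for inhibition, read by MTT assay, with a stated time of 48 h; a higher number here means a weaker inhibitor, a lower number a stronger inhibitor. The shared core is kept throughout; only the group on the amide carbonyl changes. Compound 3 carries the highest of the three numbers, but this says little: a 1.2-fold higher number from compound 1 to compound 3 (0.08 log units; within the scatter) and a 1.5-fold higher number from compound 2 to compound 3 (0.18 log units; within the scatter) are both within the scatter, as is a 1.3-fold lower number from compound 1 to compound 2 (0.10 log units; within the scatter), so the three amide variants are not separated by this assay.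

Compound 4 `COc1ccc(/C=C/c2cc(OC)cc(OC)c2/C=C/C(=O)N2CCC(c3ccccc3)CC2)cc1` extends compound 3 by phenyl in place of hydrogen on a saturated ring carbon. Among the measured compounds shown here, no measured step covers a substituent on the saturated ring itself; the steps that bear on it are those at the amide nitrogen, and each of them was within the scatter. A change at the same region that enters a phenyl therefore carries no indication from this set of a step beyond the scatter in this assay, in either direction, and the expectation is a number close to that of compound 3.

For compound 4 the estimated value in this assay is 10000 nM, with a range of 3000 nM to 35000 nM, which means an expected step of a 1.1-fold lower number from compound 3 to compound 4 (0.03 log units; within the scatter).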

Compound 4, half-maximal inhibitory concentration: 6690 nM
For compound 4 the middle estimate is 1.5-fold (0.17 log units) above the measured one; the range from low to high includes it.
By their numbers in this assay, from the lowest: compounds 4, 2, 1 and 3 (each within the scatter of the next).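

In this assay, among the compounds shown here, the only step in this set on a saturated ring carbon, three ring bonds from the ring nitrogen, is a 1.6-fold lower number from compound 3 to compound 4 (0.20 log units; within the scatter); a phenyl in place of hydrogen at this position, with its 6 heavy atoms, therefore does not separate the two compounds. The comparisons with the secondary amides read the same way, with a 1.0-fold lower number from compound 2 to compound 4 (0.02 log units; within the scatter) and a 1.3-fold lower number from compound 1 to compound 4 (0.12 log units; within the scatter), so 4-phenylpiperidin-1-yl on the carbonyl carbon is not separated from propargylamino or cyclopropylamino, and the four amide variants remain one group. No supporting measurement bears on this result, and the data give no explanation for it.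

Still open, as far as these compounds go, is whether an amine or a carboxylic acid on the entering phenyl, or a longer chain joining that phenyl to the saturated ring carbon, would give a step beyond the scatter. Changes to the shared core, such as hydroxyl in place of a methoxy group, also remain open, and with them the question of which part of the series can move the number in this assay.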